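A few compounds are considered here, and "the series" means these few. Any claim that something is new, unique, unknown or untested is made for them only; others in the source may bear on it.

Measured in a functional assay on VCaP cells (Homo sapiens) for antiproliferative activity, read by CCK-8 assay, with a stated time of 6 days; a higher number here means a weaker inhibitor, a lower number a stronger inhibitor:
- Compound 1 `C[C@@H](Cn1ccc(-c2ccc(C#N)c(Cl)c2)n1)NC(=O)C1CC(=O)C1`: 22500 nM
- Compound 2 `C[C@@H](Cn1ccc(-c2ccc(C#N)c(Cl)c2)n1)NS(=O)(=O)c1cccnc1`: 2450 nM
- Compound 3 `C[C@@H](Cn1ccc(-c2ccc(C#N)c(Cl)c2)n1)Nc1cncnc1`: > 30000 nM

The entry for compound 3 is a limit of the assay and not a number. Compound 3 therefore stands at the limit of > 30000 nM in this assay, at which 1 of the 3 values shown sits, and its true position is not known.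

Compound 4 `C[C@@H](Cn1ccc(-c2ccc(C#N)c(Cl)c2)n1)Nc1nccc(Cl)n1` keeps the shared core and carries 4-chloropyrimidin-2-yl in place of pyrimidin-5-yl on an amine nitrogen. Both groups are six-membered aromatic rings with 2 hetero atoms, so the swap stays within one kind of substituent.

Within the data shown here, no measured step makes this exact change. The nearest evidence is the set of swaps on the same nitrogen. The step of a 9.2-fold lower number from compound 1 to compound 2 (0.96 log units; beyond the scatter) was modest, and the step of an at least 12-fold higher number from compound 2 to compound 3 (1.08 log units; beyond the scatter) was large. The step of an at least 1.3-fold higher number from compound 1 to compound 3 (0.12 log units; that floor lies within the scatter) has a floor that lies within the scatter. These steps show that this nitrogen's substituent can shift the reading considerably in this assay. Since compound 3 gives > 30000 nM as a limit, only a move toward a lower number could be seen as a number, and a modest one is expected.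

Compound 4 is estimated at 12000 nM, with an expected range of 3000 nM to 30000 nM. This estimate means an expected at least 2.5-fold lower number from compound 3 to compound 4 (0.39 log units; beyond the scatter).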

Compound 4, half-maximal inhibitory concentration: > 30000 nM
Compound 4: only a limit was reported; the forecaster's own chance of this, stated with the estimate: 35%; middle value at least 2.5-fold (0.39 log units) from the limit.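

In this assay, compound 4, like compound 3, ends at a limit of the assay and not at a number: the limit of > 30000 nM in this assay, at which 2 of the 4 values shown sit. Two different six-membered aromatic rings with 2 hetero atoms on this amine nitrogen, one of them carrying a chlorine, therefore reach the same limit, and the step between them cannot be read. The (pyridin-3-yl)sulfonyl group of compound 2 stays clearly apart from the new ring, with an at least 12-fold higher number from compound 2 to compound 4 (1.08 log units; beyond the scatter), while the comparison with the (3-oxocyclobutyl)carbonyl group gives only an at least 1.3-fold higher number from compound 1 to compound 4 (0.12 log units; that floor lies within the scatter), so the gap to the sulfonyl compound is the only one of these two that is a firm separation.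

The compounds shown leave open how far compound 3 and compound 4 lie past the limit, and so whether the chlorine has any effect in this series. They also leave open whether a pyrimidin-2-yl ring without chlorine, or a simple methanesulfonyl or benzenesulfonyl group on the same nitrogen, would give a reading nearer to that of compound 2.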